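The source may hold more compounds than are shown below. What is called first, only, known or untested is meant among the compounds shown, and "the series" means these compounds.

Compound 1 `O=C1NC(=O)/C(=C/c2ccc(OCCSc3nnc(-c4ccccc4)[nH]3)cc2)S1` and compound 2 `O=C1NC(=O)/C(=C/c2ccc(OCCSc3nnc(Cc4ccccc4)[nH]3)cc2)S1` share one core; in a functional assay on the whole organism (plasma, strain Wistar) with Rattus norvegicus as the target, with a stated time of 15 days, at a dose of 3 mg/kg by the oral route (a higher number here means a stronger effect of the compound at the dose given, a lower number a weaker effect), compound 1 gives 10.4% and compound 2 gives 18.3%. The change between them, (benzyl in place of phenyl on an aromatic carbon), made a step of a number 7.9 percentage points higher from compound 1 to compound 2 (within the scatter). Compound 3 `O=C1NC(=O)/C(=C/c2ccc(OCCSc3nnc(-c4ccccc4)o3)cc2)S1` carries a different core; the difference between the two cores is not broken down here. In this assay compound 3 gives 11.6%. Compound 4 `O=C1NC(=O)/C(=C/c2ccc(OCCSc3nnc(Cc4ccccc4)o3)cc2)S1` has not yet been measured. It differs from compound 3 by benzyl in place of phenyl on an aromatic carbon, the same kind of change as that from compound 1 to compound 2, though here the place is on a five-membered aromatic ring with 2 nitrogen and 1 oxygen, next to the ring nitrogen and next to the ring oxygen, rather than on a ring with 3 nitrogen, between two ring nitrogen atoms. Compound 4 is expected to show a step of a number 6.4 percentage points higher from compound 3 to compound 4 (within the scatter) because the earlier step was a number 7.9 percentage points higher from compound 1 to compound 2 (within the scatter). Compound 4 is therefore estimated at 18%, with a likely range from 6% to 30%.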

Compound 4, a percentage reported as activity, at one dose (the size of the read-out at that dose, not a potency): 14.2%
Compound 4: the middle estimate sits 3.8 percentage points above what was measured; measured number inside the range.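

In this assay, benzyl in place of phenyl on an aromatic carbon made a step of a number 2.6 percentage points higher from compound 3 to compound 4 (within the scatter). Set beside the earlier step, this gives no sign that the change behaves differently on the two cores: the same change on two cores in this assay, a number 7.9 percentage points higher (within the scatter) from compound 1 to compound 2 and a number 2.6 percentage points higher (within the scatter) from compound 3 to compound 4, 5.3 percentage points apart, within the scatter of two such steps. That agreement is weak support for carrying the change across, since each step lies within the scatter on its own, so the data do not show that the change has a real effect on either core.

The compounds shown leave open whether a longer chain, such as phenethyl, would give a step beyond the scatter on either core. They also leave open what an amine or a carboxylic acid on the phenyl ring would do.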